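A few compounds are considered here, and "the series" means these few. Any claim that something is new, unique, unknown or untested is made for them only; others in the source may bear on it.

Measured in an ADME assay on microsomes from liver (Homo sapiens) for metabolic stability, with a stated time of 10 min; on this read-out higher numbers stand for a more stable compound and lower numbers for a less stable compound:
- compound 1 `FC(F)(F)c1ccccc1-c1cc(Cl)c2[nH]c(C3=NOC4(CCCCC4)C3)nc2c1` gives 92%
- compound 2 `OCCCc1cc(-c2ccccc2C(F)(F)F)cc2nc(C3=NOC4(CCCCC4)C3)[nH]c12` gives 57%
- compound 3 `FC(F)(F)c1ccccc1-c1ccc2[nH]c(C3=NOC4(CCOCC4)C3)nc2c1` gives 98%

Compound 3 lies within the scatter of compound 1 and clearly above compound 2. Compound 4 `FC(F)(F)c1ccccc1-c1cc(Cl)c2[nH]c(C3=NOC4(CCOCC4)C3)nc2c1` has chloro in place of hydrogen on an aromatic carbon and remains unmeasured. Among the measured compounds shown here, the one measured step shows a number 35 percentage points lower from compound 1 to compound 2 (beyond the scatter) when 3-hydroxypropyl replaces chloro, so it does not compare chloro with hydrogen directly. Still, chloro is present in compound 1 (92%), so no step beyond the scatter is expected in this assay. The expected change is a number 5 percentage points lower from compound 3 to compound 4 (within the scatter) and would stay within the scatter. For compound 4 the estimated value is 93%, with an expected range from 82% to 100%.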

Compound 4, percent of the compound remaining: 100%
Compound 4: middle estimate off by 7 percentage points, on the low side; low and high end bracket the measured number.
By their numbers in this assay, from the lowest: compound 2; then compounds 1, 3 and 4 (each within the scatter of the next).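

In this assay, among the compounds shown here, chloro in place of hydrogen on an aromatic carbon, ortho to a fused ring, gives a number 2 percentage points higher from compound 3 to compound 4 (within the scatter) and is the first direct comparison of these two groups at this position. With chloro in place, a six-membered non-aromatic ring with 1 hetero atom instead of one of carbon only gives a number 8 percentage points higher from compound 1 to compound 4 (within the scatter), so this change also leaves the read-out within the scatter. No measured evidence bears on the reason for either result. On these data alone, how an amine or a carboxylic acid would behave at this position remains open, as does the effect of a chain longer than 3-hydroxypropyl.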